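Fluoro for Methyl on a Near-Inactive Quinoline Amide Series

The compounds below may be only part of what the source reports. "The series", "measured", "known", "first", "only" and "open" are said of these compounds alone.

Measured compounds:
- Compound 1 `Cc1ccc2nc(C(=O)Nc3c(F)cc(-c4cccc(F)c4)cc3F)c(C)c(O)c2c1`: 0.98%
- Compound 2 `Cc1c(C(=O)Nc2c(F)cc(-c3cccc(F)c3)cc2F)nc2ccc(F)cc2c1O`: 0.35%
- Compound 3 `Cc1ccc2nc(C(=O)Nc3c(F)cc(-c4cccc(F)c4)cc3F)c(C)c(C(=O)O)c2c1`: 1.05%

All three compounds were tested in a functional assay on Hep 3B2 cells (Homo sapiens) for antiproliferative activity, read by MTT assay, with a stated time of 24 h, tested at 0.02 ug/mL; a higher number here means a stronger effect of the compound at the concentration tested, a lower number a weaker effect. Compound 1 gives 0.98% in this assay, compound 2 gives 0.35%, and compound 3 gives 1.05%. Compound 3 holds the highest of the three numbers, but its nearest neighbour, compound 1, sits only a number 0.1 percentage points higher from compound 1 to compound 3 (within the scatter) away, and compound 2 is no further off than the scatter allows, so the three cannot be ordered against one another.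

The next compound, compound 4 `Cc1c(C(=O)Nc2c(F)cc(-c3cccc(F)c3)cc2F)nc2ccc(F)cc2c1C(=O)O`, has not yet been measured. It differs from compound 3 in one place: fluoro in place of methyl on an aromatic carbon

Among the measured compounds shown here, one measured step bears directly on this change, because the same exchange was made on the hydroxy-bearing pair: a number 0.6 percentage points lower from compound 1 to compound 2 (within the scatter). That step stayed within the scatter. Nothing else among the measured compounds speaks to the exchange. The expectation for compound 4 is therefore a step of a number 0.6 percentage points lower from compound 3 to compound 4 (within the scatter), that is, no movement beyond the scatter.

Compound 4 is accordingly estimated at 0.5% in this assay, with an expected range from -7% to 8%.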

Compound 4, a percentage reported as inhibition, at one concentration (the size of the read-out at that concentration, not a potency): -0.13%
Estimate against measurement, compound 4: 0.6 percentage points above; measured number inside the range.
By their numbers in this assay, from the lowest: compounds 4, 2, 1 and 3 (each within the scatter of the next).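

In this assay, the exchange of fluoro for methyl on this aromatic carbon, now made on the carboxy-bearing core as well as the hydroxy-bearing one, gives a number 1.2 percentage points lower from compound 3 to compound 4 (within the scatter). The exchange therefore stays within the scatter on a second core, and its size does not depend measurably on which of the two cores carries it: the same change on two cores in this assay, a number 0.6 percentage points lower (within the scatter) from compound 1 to compound 2 and a number 1.2 percentage points lower (within the scatter) from compound 3 to compound 4, 0.6 percentage points apart, within the scatter of two such steps. Among the compounds shown here, the new compound also gives the exchange of carboxy for hydroxy a second reading, a number 0.5 percentage points lower from compound 2 to compound 4 (within the scatter), which matches the first reading on the methyl-bearing pair: the same change on two cores in this assay, a number 0.1 percentage points higher (within the scatter) from compound 1 to compound 3 and a number 0.5 percentage points lower (within the scatter) from compound 2 to compound 4, 0.6 percentage points apart, within the scatter of two such steps.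

None of the steps shown leaves the scatter at this single concentration, so they cannot tell whether methyl or fluoro at this position would matter in a compound with a larger effect. Going by these compounds, it remains open whether a chlorine, a methoxy or an amine on the same aromatic carbon would move the number beyond the scatter, and how these compounds would behave at a higher concentration.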